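From a Saturated Ring Back to an Aromatic One

The source may report more compounds than this note shows. Statements on the series, on what has been measured and on what is new or still open speak of the compounds shown alone.

Three compounds have so far been measured in an in vitro assay on CHO cells for displacement of a labelled ligand from Bombesin receptor subtype-3 (Homo sapiens), read by scintillation counting, with a stated time of 2 h; a lower number here means a stronger inhibitor, a higher number a weaker inhibitor:
compound 1 `CCC(C)(C)Cc1c[nH]c(CCc2ccc(-c3cccnc3)cc2)n1` gives 7.5 nM
compound 2 `CCC(C)(C)Cc1c[nH]c(CCc2ccc(-n3ncnn3)cc2)n1` gives 205 nM
compound 3 `CCC(C)(C)Cc1c[nH]c(CCc2ccc(N3CCCCC3)cc2)n1` gives 28 nM

All three share one core and differ only in the group attached to an aromatic carbon of the outer ring. Compound 3 stands second of the three numbers: the step of a 3.7-fold higher number from compound 1 to compound 3 (0.57 log units; beyond the scatter) places it behind compound 1, while the step of a 7.3-fold lower number from compound 2 to compound 3 (0.86 log units; beyond the scatter) places it well ahead of compound 2.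

Compound 4 `CCC(C)(C)Cc1c[nH]c(CCc2ccc(-c3ccc(F)cn3)cc2)n1` has not yet been measured in this assay. Its change from compound 3 is 5-fluoropyridin-2-yl in place of piperidin-1-yl on an aromatic carbon. The step that bears most on it is a 27-fold higher number from compound 1 to compound 2 (1.44 log units; beyond the scatter), where a six-membered aromatic ring with one nitrogen gave way to a small five-membered ring and the number rose sharply; the step of a 3.7-fold higher number from compound 1 to compound 3 (0.57 log units; beyond the scatter) shows that the same aromatic ring also beats the saturated ring. Compound 4 restores a six-membered aromatic ring with one nitrogen, so a move toward the number of compound 1 is expected. Going by the values given here, the fluorine and the nitrogen placement of compound 4 have no counterpart among the measured compounds, which holds the expectation short of the full number of compound 1. For compound 4 the expected step is a 2.3-fold lower number from compound 3 to compound 4 (0.37 log units; beyond the scatter). Compound 4 is therefore estimated at 12 nM, with a range from 4 nM to 40 nM.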

Compound 4, half-maximal inhibitory concentration: 19 nM
The estimate for compound 4 lay 1.6-fold (0.20 log units) below the measured number; measured number inside the range.
By their numbers in this assay, from the lowest: compound 1; then compounds 4 and 3 (each within the scatter of the next); then compound 2.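

In this assay, exchanging the saturated ring for an aromatic one at this position gives a 1.5-fold lower number from compound 3 to compound 4 (0.17 log units; within the scatter), so an aromatic ring of this size does not by itself separate compound 4 from the piperidin-1-yl group of compound 3. Two six-membered aromatic rings with one hetero atom also need not behave alike here: the step is a 2.5-fold higher number from compound 1 to compound 4 (0.40 log units; beyond the scatter), showing that the details of the ring matter even when its size and type stay the same. At the same time, an 11-fold lower number from compound 2 to compound 4 (1.03 log units; beyond the scatter) shows that 5-fluoropyridin-2-yl, like the other two six-membered rings, gives a clearly lower number than the 2H-tetrazol-2-yl group of compound 2.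

No measurement at hand explains these differences. As far as these compounds go, the gap between compound 1 and compound 4 combines a fluorine with a different nitrogen placement, so the separate contribution of each stays open, and a pyridin-2-yl group without fluorine would separate them, while an open-chain amine on the same aromatic carbon would test whether a ring is needed at all.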